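Urea aryl variation in the LOX IMVI growth assay

The compounds below may be only part of what the source reports. "The series", "measured", "known", "first", "only" and "open" are said of these compounds alone.

Measured so far:
compound 1 `COc1cc(Cl)cc(-c2nn(-c3cccc(NC(=O)Nc4ccc(Cl)c(C(F)(F)F)c4)c3)cc2-c2ccncc2)c1` — 97%
compound 2 `COc1cc(Cl)cc(-c2nn(-c3cccc(NC(=O)Nc4ccc(Cl)c(Cl)c4)c3)cc2-c2ccncc2)c1` — 94%

Both measured compounds act weakly in a functional assay on LOX IMVI cells (Homo sapiens) for inhibition, read by sulforhodamine B assay, with a stated time of 48 h, tested at 0.1 uM; on this read-out higher numbers stand for a weaker effect at the one concentration tested and lower numbers for a stronger effect. Compound 1 gives 97% and compound 2 gives 94%; the step of a number 3 percentage points lower from compound 1 to compound 2 (within the scatter) is within the scatter, so the two values cannot be told apart, and compound 2 is simply the second of two close numbers.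

Compound 3 `COc1cc(Cl)cc(-c2nn(-c3cccc(NC(=O)Nc4cccc(C(F)(F)F)c4)c3)cc2-c2ccncc2)c1` is not yet measured. It differs from compound 2 by 3-(trifluoromethyl)phenyl in place of 3,4-dichlorophenyl on an amide-type nitrogen. Going by the values given here, the only measured step that bears on this is the exchange of chloro for trifluoromethyl on the same urea-bound aromatic ring, a number 3 percentage points lower from compound 1 to compound 2 (within the scatter), which stayed within the scatter. A second alteration on that ring is therefore expected to leave the read-out in this assay essentially unchanged, with no step beyond the scatter; the expected step is a number 1 percentage points higher from compound 2 to compound 3 (within the scatter). Compound 3 is thus estimated at 95%, expected between 85% and 102%.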

Compound 3, a percentage reported as activity, at one concentration (the size of the read-out at that concentration, not a potency): 97%
Estimate against measurement, compound 3: 2 percentage points below; the range from low to high includes it.
By their numbers in this assay, from the lowest: compounds 2, 1 and 3 (each within the scatter of the next).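

In this assay, going by these compounds alone, 3-(trifluoromethyl)phenyl in place of 3,4-dichlorophenyl on the amide-type nitrogen gives a number 3 percentage points higher from compound 2 to compound 3 (within the scatter), and hydrogen in place of chloro on an aromatic carbon, a change not covered by the earlier compounds, gives no change at the digits printed from compound 1 to compound 3 (within the scatter), so neither exchange can be told from the scatter. On this ring, the chloro of compound 1 can therefore be lost, and the trifluoromethyl of compound 3 can stand in for both chloro groups of compound 2, with no readable difference at this one concentration.

As far as these compounds go, whether any group on this nitrogen can move the read-out beyond the scatter stays open. An amine, a carboxylic acid or a longer alkyl chain on the ring would test that. Nothing available explains why these values stay so close.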